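Methoxy to Methylsulfanyl: A Step Within Scatter Expected

This account rests on a few compounds, and the source may have more. Where it says the series, first, only, none or still open, it means among the compounds named here.

Compound 2 `COc1ccc(CNc2nc(SC)nc3ccccc23)cc1` is one of two compounds measured in a functional assay on MCF7 cells (Homo sapiens) for cytotoxicity, read by MTT assay, with a stated time of 72 h (a higher number here means a weaker inhibitor of growth, a lower number a stronger inhibitor of growth), and in this assay compound 2 gives 85100 nM, the only plain number shown. Compound 1 `CSc1nc(NCc2ccc([Se]C)cc2)c2ccccc2n1` returns only a limit of the assay, > 100000 nM, not a number. The step of an at least 1.1-fold lower number from compound 1 to compound 2 (0.07 log units; that floor lies within the scatter) starts from that limit (the limit of > 100000 nM in this assay, at which 1 of the 2 values shown sits). Compound 3 `CSc1ccc(CNc2nc(SC)nc3ccccc23)cc1` differs from compound 2 by methylsulfanyl in place of methoxy on an aromatic carbon. Among the measured compounds shown here, the one comparable exchange on an aromatic carbon, an at least 1.1-fold lower number from compound 1 to compound 2 (0.07 log units; that floor lies within the scatter), stayed within the scatter, so the expected step of a 1.0-fold lower number from compound 2 to compound 3 (0.00 log units; within the scatter) in this assay is also within the scatter. Compound 3 is therefore estimated at 85000 nM, within 40000 nM to 200000 nM.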

Compound 3, concentration for total growth inhibition: > 100000 nM
Compound 3: no number, only a limit (the forecaster's own chance of this, stated with the estimate: 35%); at least 1.1-fold (0.07 log units) between middle value and limit.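

Methylsulfanyl in place of methoxy on this aromatic carbon gives an at least 1.1-fold higher number from compound 2 to compound 3 (0.07 log units; that floor lies within the scatter) in this assay. Going by these compounds, the value of compound 3 is a limit of the assay and not a number, so this exchange shows no step beyond the scatter, yet its true size stays unknown. The step from compound 1 to compound 3 cannot be read, and compound 2 alone keeps a plain number: the limit of > 100000 nM in this assay, at which 2 of the 3 values shown sit.

Still open, on these data alone, is how far compound 3 really lies from compound 2. Also open, as far as these compounds go, is whether an amine or a carboxylic acid at this position would give a clearly lower number.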